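A few compounds are considered here, and "the series" means these few. Any claim that something is new, unique, unknown or untested is made for them only; others in the source may bear on it.

Measured compounds in an assay on isolated protein for inhibition of Amine oxidase [flavin-containing] B (Homo sapiens), read by fluorescence and Amplex Red, with a stated time of 15 min; on this read-out lower numbers stand for stronger inhibition and higher numbers for weaker inhibition:
- compound 1, `C#CCN(C)Cc1cn(-c2cc(NC(=S)NCC)ncn2)cn1`, gives 1430 nM
- compound 2, `C#CCN(CCC)Cc1cn(-c2cc(NC(=S)NCC)ncn2)cn1`, gives > 50000 nM
- compound 3, `C#CCN(CCCC)Cc1cn(-c2cc(NC(=S)NCC)ncn2)cn1`, gives > 50000 nM

Compound 3 stands at the edge of what this assay can read: its value is a limit, not a number. The same holds for compound 2, whose value is also a limit (the limit of > 50000 nM in this assay, at which 2 of the 3 values shown sit). Only compound 1, which carries the smallest group on the amine nitrogen, returns a true number.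

Compound 4, `C#CCN(Cc1cn(-c2cc(NC(=S)NCC)ncn2)cn1)C(C)=O`, is the next step. The change is acetyl in place of butyl on an amine nitrogen. Within the data shown here, two measured steps bear on it: an at least 34-fold higher number from compound 1 to compound 2 (1.54 log units; beyond the scatter) and an at least 34-fold higher number from compound 1 to compound 3 (1.54 log units; beyond the scatter), both showing that enlarging the group on this nitrogen beyond methyl pushes the value out of range. The step that the two limits leave unreadable from compound 2 to compound 3 adds nothing readable. Acetyl is smaller than butyl, yet no measured compound carries a group of this kind on the nitrogen, so the outcome is uncertain. Compound 4 is expected to stay weak, with the step of an at least 1.6-fold lower number from compound 3 to compound 4 (0.22 log units; that floor lies within the scatter) small and uncertain. The estimate for compound 4 in this assay is 30000 nM, expected between 5000 nM and 60000 nM.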

Compound 4, half-maximal inhibitory concentration: > 50000 nM
Compound 4: only a limit was reported; the forecaster's own chance of this, stated with the estimate: 50%; at least 1.6-fold (0.22 log units) between middle value and limit.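

Compound 4 shows that the loss on this amine nitrogen is not limited to saturated chains: acetyl, which carries a hydrogen-bond acceptor that butyl lacks, also leaves inhibition out of reach in this assay, with an at least 34-fold higher number from compound 1 to compound 4 (1.54 log units; beyond the scatter). The value of compound 4, > 50000 nM, is a limit and not a number, so its steps to compound 2 and compound 3 cannot be read. Methyl in compound 1 is now the only group on this nitrogen that gives a true number, and the other three compounds sit at one edge of the assay: the limit of > 50000 nM in this assay, at which 3 of the 4 values shown sit.

The compounds shown leave open whether ethyl, or a plain hydrogen, on this nitrogen would still give a readable value. They also leave open how compound 2, compound 3 and compound 4 rank against one another.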